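Series notes: estimating compound 4 from compound 2

A few compounds are considered here, and "the series" means these few. Any claim that something is new, unique, unknown or untested is made for them only; others in the source may bear on it.

Measured so far in an ADME assay on HeLa cells (Homo sapiens) for inhibition, read by cell counting; a higher number here means a weaker inhibitor, a lower number a stronger inhibitor:
compound 1 `CSc1nc(NCCCNc2ccnc3cc(Cl)ccc23)c(C#N)c(-c2ccccc2)n1` gives 11000 nM
compound 2 `CSc1nc(NCCCCNc2ccnc3cc(Cl)ccc23)c(C#N)c(-c2cccc([N+](=O)[O-])c2)n1` gives 1100 nM
compound 3 `CSc1nc(-c2ccc([N+](=O)[O-])cc2)c(C#N)c(N2CCN(c3ccnc4cc(Cl)ccc34)CC2)n1` gives 228000 nM

Compound 2 stands lowest of the three numbers, and both gaps to it lie beyond the scatter: compound 1 gives a higher number, and compound 3 gives a much higher number still. Compound 2 is thus the strongest inhibitor measured in this assay. No pair among these three differs in only one place, so no single-point step can be read from them.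

Compound 4 `COc1ccc(-c2nc(SC)nc(NCCCCNc3ccnc4cc(Cl)ccc34)c2C#N)cc1OC` differs from compound 2 in one place: 3,4-dimethoxyphenyl in place of 3-nitrophenyl on an aromatic carbon. Nothing measured isolates this exchange. Compound 1 carries a plain phenyl at this place but also differs in its chain, so its number of 11000 nM is only a loose pointer. For compound 4 a step in this assay toward a higher number is expected, of modest size, possibly not beyond the scatter, namely a 2.7-fold higher number from compound 2 to compound 4 (0.44 log units; beyond the scatter). The estimate for compound 4 is 3000 nM, with a range from 800 nM to 12000 nM.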

Compound 4, half-maximal inhibitory concentration: 20000 nM
Estimate against measurement, compound 4: 6.7-fold (0.82 log units) below, and the stated range ends below it.
By their numbers in this assay, from the lowest: compound 2; then compounds 1 and 4 (each within the scatter of the next); then compound 3.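

In this assay, among the compounds shown here, the exchange of 3-nitrophenyl for 3,4-dimethoxyphenyl on the aromatic carbon ortho to the cyano group gives an 18-fold higher number from compound 2 to compound 4 (1.26 log units; beyond the scatter), the first step that can be read at a single place. With the rest of the structure held the same, the group at this position alone moves the number well beyond the scatter, toward a weaker inhibitor. No evidence on hand accounts for the size of this step.

The exchange removes a nitro group and adds two methoxy groups at once, so the compounds shown cannot say which part of the change carries the step. As far as these compounds go, how a plain phenyl, a 3-methoxyphenyl or a 3-aminophenyl at this position on the same chain would compare remains open.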